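Methyl to fluoro at a new place: expected outcome for compound 4

The source may hold more compounds than are shown below. What is called first, only, known or untested is meant among the compounds shown, and "the series" means these compounds.

The three measured compounds share one core, carried by compound 1 `Cc1ccc(-c2nn(-c3ccccc3)cc2-c2nc3ccccc3n2S(=O)(=O)c2ccc(C)cc2)cc1`, compound 2 `Cc1ccc(-c2nn(-c3ccccc3)cc2-c2nc3ccccc3n2S(=O)(=O)c2ccc(F)cc2)cc1` and compound 3 `Cc1ccc(-c2nn(-c3ccccc3)cc2-c2nc3ccccc3n2S(=O)(=O)c2ccc(C(F)(F)F)cc2)cc1`. In a functional assay on HepG2 cells (Homo sapiens) for antiproliferative activity, read by MTT assay, with a stated time of 24 h (a higher number here means a weaker inhibitor, a lower number a stronger inhibitor), compound 1 gives 520 nM, compound 2 gives 5060 nM and compound 3 gives 1930 nM. Among these three numbers compound 3 stands second highest: the nearest number is that of compound 2, the step being a 2.6-fold lower number from compound 2 to compound 3 (0.42 log units; beyond the scatter), and the furthest is that of compound 1, the step being a 3.7-fold higher number from compound 1 to compound 3 (0.57 log units; beyond the scatter).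

Compound 4 `O=S(=O)(c1ccc(C(F)(F)F)cc1)n1c(-c2cn(-c3ccccc3)nc2-c2ccc(F)cc2)nc2ccccc21` has not yet been measured. Relative to compound 3 the change is fluoro in place of methyl on an aromatic carbon. For the measured compounds named here, one measured step bears on it: the same substitution, fluoro in place of methyl on an aromatic carbon, made at a different place in the core, gave a 9.7-fold higher number from compound 1 to compound 2 (0.99 log units; beyond the scatter). Going by the values given here, whether the effect carries over to the new place cannot be read from the data; the one available reading points toward a higher number, and a smaller shift is assumed since the place differs. Compound 4 is therefore expected to give a higher number, estimated at 5000 nM, within 1900 nM to 15000 nM. The estimate implies an expected step of a 2.6-fold higher number from compound 3 to compound 4 (0.41 log units; beyond the scatter).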

Compound 4, half-maximal inhibitory concentration: 1680 nM
Compound 4: the middle estimate sits 3.0-fold (0.47 log units) above what was measured; the whole stated range lies above it.
By their numbers in this assay, from the lowest: compound 1; then compounds 4 and 3 (each within the scatter of the next); then compound 2.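

In this assay, replacing 4-methylphenyl with 4-fluorophenyl at this position, with trifluoromethyl held at the other varied place, gives a 1.1-fold lower number from compound 3 to compound 4 (0.06 log units; within the scatter), so the change has no readable effect here. The earlier compounds shown here showed this substitution only at the other place, where it raised the number, and that shift does not carry over to this position: the same change on two cores in this assay, a 9.7-fold higher number (0.99 log units; beyond the scatter) from compound 1 to compound 2 and a 1.1-fold lower number (0.06 log units; within the scatter) from compound 3 to compound 4, 11-fold (1.05 log units) apart, beyond the scatter of two such steps In this assay, methyl and fluoro at this position therefore cannot be told apart when trifluoromethyl occupies the other place, and the earlier step describes only its own place and partner groups.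

Still open, as far as these compounds go, is whether this position stays as flat with methyl or fluoro at the other varied place, since the present reading comes from a single pair carrying trifluoromethyl there. Also open, from the compounds shown here alone, is how a methoxy group, an amine or a carboxylic acid at this position would read in this assay, as methyl and fluoro alone do not show whether the position responds to any substitution.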